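Swapping a Triazole for a Thiophene on the Benzyl Arm

The source may hold more compounds than are shown below. What is called first, only, known or untested is meant among the compounds shown, and "the series" means these compounds.

Measured so far:
compound 1, `Cc1cc(C)c(NC(=O)N(Cc2ccc(-c3ccccc3)s2)C2CCCCCC2)c(C)c1`, 46 nM
compound 2, `Cc1cc(C)c(NC(=O)N(Cc2ccc(-c3n[nH]c(C)n3)cc2)C2CCCCCC2)c(C)c1`, 120 nM
compound 3, `Cc1cc(C)c(NC(=O)N(Cc2cccc(-c3csc(C)n3)c2)C2CCCCCC2)c(C)c1`, 180 nM

All three were tested in an assay on microsomes from intestine for inhibition of acyl-CoA:cholesterol acyltransferase (Oryctolagus cuniculus); a lower number here means a stronger inhibitor, a higher number a weaker inhibitor. Compound 2 stands second highest of the three numbers; its nearest neighbour is compound 3, whose value lies within the scatter, while compound 1 sits furthest away with a clearly lower number.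

Compound 4, `Cc1cc(C)c(NC(=O)N(Cc2ccc(-c3ccsc3)cc2)C2CCCCCC2)c(C)c1`, has not yet been measured. It differs from compound 2 in one place: thiophen-3-yl in place of 5-methyl-1H-1,2,4-triazol-3-yl on an aromatic carbon. Among the compounds with values here, no directly comparable step has been measured, so the expected size rests on compound 1, which also carries a thiophene ring and gives 46 nM. On that basis compound 4 is expected to show a lower number than compound 2, a step of a 2.0-fold lower number from compound 2 to compound 4 (0.30 log units; within the scatter), with an estimate of 60 nM, somewhere between 25 nM and 150 nM.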

Compound 4, half-maximal inhibitory concentration: 19 nM
Estimate against measurement, compound 4: 3.2-fold (0.50 log units) above; measured number outside the range, below it.
By their numbers in this assay, from the lowest: compound 4; then compound 1; then compounds 2 and 3 (each within the scatter of the next).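

In this assay, within the data shown here, the change from 5-methyl-1H-1,2,4-triazol-3-yl to thiophen-3-yl brings a 6.3-fold lower number from compound 2 to compound 4 (0.80 log units; beyond the scatter) and is the first single-place comparison in this set. It shows that this place, para to a large group, responds to which five-membered aromatic ring it carries, and that the ring with 1 hetero atom and 0 hydrogen-bond donors gives the lower number. Nothing available explains the step. Going by these compounds, whether a furan or pyridine ring would behave like thiophen-3-yl remains open. So does whether the triazole's methyl or its ring nitrogens matter more.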